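A few compounds are considered here, and "the series" means these few. Any claim that something is new, unique, unknown or untested is made for them only; others in the source may bear on it.

Working notes on the series: in a functional assay on HepG2 cells (Homo sapiens) for cytotoxicity, read by MTT assay, with a stated time of 72 h (on this read-out lower numbers stand for stronger inhibition and higher numbers for weaker inhibition), compound 1 (`COc1cc2ncnc(Nc3ccc(F)c(Cl)c3)c2cc1NC(=O)N/N=C/c1ccc([N+](=O)[O-])cc1`) gives 34100 nM and compound 2 (`COc1ccc(/C=N/NC(=O)Nc2cc3c(Nc4ccc(F)c(Cl)c4)ncnc3cc2OC)cc1`) gives 21300 nM on the same read-out, so compound 2 stands within the scatter of the only other measured value and no order can be drawn between the two. Not yet measured is compound 3 (`COc1cc2ncnc(Nc3ccc(F)c(Cl)c3)c2cc1NC(=O)N/N=C/c1ccc(O)cc1`), which differs from compound 2 as follows: hydrogen in place of methyl on an oxygen on an aromatic ring (hydrogen in place of methyl on an oxygen on an aromatic ring, that is, methoxy to hydroxy). Among the measured compounds shown here, only one measured step bears on this change, and only loosely: a 1.6-fold lower number from compound 1 to compound 2 (0.20 log units; within the scatter) was methoxy in place of nitro on an aromatic carbon and stayed within the scatter. For the measured compounds named here, no measured step covers a hydroxy group, so that single step is a thin guide. On it, no change beyond the scatter is expected in this assay for this replacement. The expected step is a 1.0-fold higher number from compound 2 to compound 3 (0.01 log units; within the scatter) and would lie within the scatter. The estimate for compound 3 is 22000 nM with an expected range from 9000 nM to 50000 nM on this read-out.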

Compound 3, half-maximal inhibitory concentration: 26300 nM
The estimate for compound 3 lay 1.2-fold (0.08 log units) below the measured number; the measured number falls inside the stated range.
By their numbers in this assay, from the lowest: compounds 2, 3 and 1 (each within the scatter of the next).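

Working notes, continued: in this assay, removing the methyl from the oxygen on the aromatic ring gives a 1.2-fold higher number from compound 2 to compound 3 (0.09 log units; within the scatter) and so adds a second replacement at this place that stays within the scatter, now one that changes methoxy to hydroxy rather than replacing the whole group. Hydroxy in place of nitro on the same aromatic carbon gives a 1.3-fold lower number from compound 1 to compound 3 (0.11 log units; within the scatter) and closes the set of three pairs, so nitro, methoxy and hydroxy all read alike here and compounds 1, 2 and 3 cannot be ranked against one another. The series offers no measurement that would account for this flat reading at this place.

Going by these compounds, what stays open is whether any group on this aromatic carbon moves the number beyond the scatter in this assay at all, for instance an amine or a carboxylic acid in place of hydroxy, or a longer chain in place of the methyl on the oxygen. Among the compounds shown here, with only three groups compared on one shared core, nothing here shows whether the same flat reading would hold if the rest of the structure were changed.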